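The source may report more compounds than this note shows. Statements on the series, on what has been measured and on what is new or still open speak of the compounds shown alone.

Compound 1 `COc1ccc(OC)c(-c2nc(C(c3ccccc3)c3ccccc3)sc2CC(=O)O)c1`: 80%
Compound 2 `COc1cc(-c2nc(C(c3ccc(F)cc3)c3ccc(F)cc3)sc2CC(=O)O)ccn1`: 60%

In an in vitro functional assay on HEK285-7 cells for antagonist activity at prostaglandin D2 receptor 2 (Homo sapiens), read by BRET and beta-arrestin recruitment (on this read-out higher numbers stand for larger maximal responses and lower numbers for smaller maximal responses), compound 1 gives 80% and compound 2 gives 60%. Compound 2 thus stands lowest of the two measured numbers, with compound 1 above it by a gap beyond the usual scatter. Compound 3 `O=C(O)Cc1sc(C(c2ccc(F)cc2)c2ccc(F)cc2)nc1-c1ccnc(N2CCCC2)c1` is the next compound, differing from compound 2 in one place: pyrrolidin-1-yl in place of methoxy on an aromatic carbon. Going by the values given here, no single-change step between measured compounds has been recorded, so this change is untested. The expected step is a number 5 percentage points higher from compound 2 to compound 3 (within the scatter), a small rise that may not exceed the scatter. For compound 3 the estimated value is 65%, with a range from 45% to 85%.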

Compound 3, largest response reached (reported as efficacy), in percent of the reference or control that the assay uses: 80%
Beside the measured number, compound 3's estimate is 15 percentage points below it, within the range that was stated.
By their numbers in this assay, from the lowest: compound 2; then compounds 1 and 3 (each within the scatter of the next).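

In this assay, replacing methoxy with pyrrolidin-1-yl on the aromatic carbon next to the ring nitrogen gives a number 20 percentage points higher from compound 2 to compound 3 (beyond the scatter). Going by these compounds alone, this is the first comparison here in which only one group changes, and it shows that the maximal response depends on the group at this position. No measurement available here explains this rise. Going by these compounds, it remains open whether the ring itself matters or only the attached nitrogen. A dimethylamino group or a piperidin-1-yl ring at the same carbon would help separate these two possibilities.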